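The source may hold more compounds than are shown below. What is called first, only, known or untested is meant among the compounds shown, and "the series" means these compounds.

Measured compounds:
compound 1, `CSCC[C@H](N)C(=O)NS(=O)(=O)OC[C@H]1OC[C@@H](n2cnc3c(N)ncnc32)[C@H](O)[C@@H]1O`: 5200 nM
compound 2, `CC(C)C[C@H](N)C(=O)NS(=O)(=O)OC[C@H]1OC[C@@H](n2cnc3c(N)ncnc32)[C@H](O)[C@@H]1O`: 1000 nM
compound 3, `CC(C)C[C@H](N)C(=O)NS(=O)(=O)OC[C@H]1O[C@@H](n2cnc3c(N)ncnc32)[C@H](O)[C@@H]1O`: 1100 nM

In a functional assay on PBMC cells (Homo sapiens) for inhibition (on this read-out lower numbers stand for stronger inhibition and higher numbers for weaker inhibition), compound 3 gives 1100 nM, the second highest of the three numbers. Compound 3 and compound 2 lie within the scatter of each other, so nothing separates them; compound 1 gives a number beyond the scatter above compound 3. Compound 2 and compound 3 differ only in the sugar part of the shared core, and their values show no change beyond the scatter from that difference.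

Compound 4 is `CCC[C@H](N)C(=O)NS(=O)(=O)OC[C@H]1O[C@@H](n2cnc3c(N)ncnc32)[C@H](O)[C@@H]1O`. The change from compound 3: hydrogen in place of methyl on a saturated chain carbon bound to two saturated chain carbons. Within the data shown here, the only measured step that touches this side chain is a 5.2-fold lower number from compound 1 to compound 2 (0.72 log units; beyond the scatter), a modest step for a change of one group to another at the same place. Removing a single carbon from the isobutyl group is a smaller change, and nothing measured here shows how shortening this chain reads. A small weakening is the expectation, not beyond doubt.

For compound 4 the expected value in this assay is 2500 nM, with a range from 1000 nM to 6500 nM. This estimate means a step of a 2.3-fold higher number from compound 3 to compound 4 (0.36 log units; beyond the scatter), expected to be modest and toward weaker inhibition.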

Compound 4, half-maximal inhibitory concentration: 4700 nM
Estimate against measurement, compound 4: 1.9-fold (0.27 log units) below, and the stated range covers the measured number.
By their numbers in this assay, from the lowest: compounds 2 and 3 (each within the scatter of the next); then compounds 4 and 1 (each within the scatter of the next).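

Going from isobutyl to propyl on the side chain is a change of hydrogen in place of methyl, and in this assay it gives a 4.3-fold higher number from compound 3 to compound 4 (0.63 log units; beyond the scatter), toward weaker inhibition. The earlier compounds shown here showed only that exchanging one whole side chain for another can move the number; this step shows that a single methyl on a saturated chain carbon bound to two saturated chain carbons is enough to do so. No supporting data bear on why this methyl matters here.

Still open, from the compounds shown here alone, is how a longer chain, such as pentyl, or a cyclohexyl or phenyl ring at this place would read. Going by these compounds, it is also open whether an amine or a carboxylic acid at the end of the propyl chain would read differently, and whether the same methyl loss reads the same on the sugar of compound 2.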